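Swapping vinyl for cyclopropyl on a thioether analogue

The source may report more compounds than this note shows. Statements on the series, on what has been measured and on what is new or still open speak of the compounds shown alone.

Among the measured compounds shown here, compound 3 `C=CC1C(=O)N(c2cc(OC)c(OC)c(OC)c2)C1c1ccc(SCC)cc1` gives 320 nM in a functional assay on HL-60 cells (Homo sapiens) for inhibition, read by resazurin assay, with a stated time of 72 h (on this read-out lower numbers stand for stronger inhibition and higher numbers for weaker inhibition), the highest of the three numbers measured so far. Compound 1 `CCOc1ccc(C2C(C3CC3)C(=O)N2c2cc(OC)c(OC)c(OC)c2)cc1` gives 201 nM, which lies within the scatter of compound 3, whereas compound 2 `C=CC1C(=O)N(c2cc(OC)c(OC)c(OC)c2)C1c1ccc(OCC)cc1` gives 35 nM, a gap beyond the scatter. Compound 4 `CCSc1ccc(C2C(C3CC3)C(=O)N2c2cc(OC)c(OC)c(OC)c2)cc1` is not yet measured; it differs from compound 3 as follows: cyclopropyl in place of vinyl on a saturated ring carbon The same exchange, taken in the other direction, has been measured once: a 5.7-fold lower number from compound 1 to compound 2 (0.76 log units; beyond the scatter). The other known step, a 9.1-fold higher number from compound 2 to compound 3 (0.96 log units; beyond the scatter), concerns a different position and bears only indirectly. On that basis a higher number for compound 4 is expected, of roughly the size seen before: a 5.6-fold higher number from compound 3 to compound 4 (0.75 log units; beyond the scatter). Compound 4 is therefore estimated at 1800 nM, with a range from 600 nM to 5500 nM.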

Compound 4, half-maximal inhibitory concentration: 803 nM
The estimate for compound 4 lay 2.2-fold (0.35 log units) above the measured number, within the range that was stated.
By their numbers in this assay, from the lowest: compound 2; then compounds 1 and 3 (each within the scatter of the next); then compound 4.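

With the ethylsulfanyl group in place, cyclopropyl instead of vinyl on the saturated ring carbon again gives a higher number, with a 2.5-fold higher number from compound 3 to compound 4 (0.40 log units; beyond the scatter) in this assay, and this step matches the one measured with ethoxy in size: the same change on two cores in this assay, a 5.7-fold lower number (0.76 log units; beyond the scatter) from compound 1 to compound 2 and a 2.5-fold lower number (0.40 log units; beyond the scatter) from compound 4 to compound 3, 2.3-fold (0.36 log units) apart, within the scatter of two such steps.
The ethylsulfanyl exchange also repeats with cyclopropyl in place, with a 4.0-fold higher number from compound 1 to compound 4 (0.60 log units; beyond the scatter) as its step, and the two sizes again agree: the same change on two cores in this assay, a 9.1-fold higher number (0.96 log units; beyond the scatter) from compound 2 to compound 3 and a 4.0-fold higher number (0.60 log units; beyond the scatter) from compound 1 to compound 4, 2.3-fold (0.36 log units) apart, within the scatter of two such steps.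
Among these four compounds, none goes against either change keeping its direction when the other place is altered.

Going by these compounds, what an ethyl group, an ethynyl group or a longer chain would give on that ring carbon stays open. So does the reading of an amine or a carboxylic acid there.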